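The compounds below may be only part of what the source reports. "The series", "measured", "known", "first", "only" and "open" are said of these compounds alone.

Measured so far in a functional assay on HEK293 cells for agonist activity at Free fatty acid receptor 1 (Homo sapiens), read by FLIPR and calcium flux; a higher number here means that more compound is needed for the effect, a lower number that less compound is needed:
compound 1 `COc1ccc(F)c([C@H]2CC[C@H](COc3cccc([C@H](C4CC4)[C@H](C)C(=O)O)c3)CC2)c1` — compound 1 gives 0.2 nM
compound 2 `COc1ccc(F)c([C@H]2CC[C@H](COc3cccc([C@H](C4CC4)[C@@H](C)C(=O)O)c3)CC2)c1` — compound 2 gives 2.2 nM

Compound 2 stands highest of the two numbers in this assay, with compound 1 as the nearest neighbour, the step being an 11-fold higher number from compound 1 to compound 2 (1.04 log units; beyond the scatter); this rests on the fact that compounds 1 and 2 differ only in the configuration as drawn and on nothing else.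

Compound 3 `COc1ccc(F)c([C@H]2CC[C@H](COc3cccc([C@H](C4CC4)[C@H](F)C(=O)O)c3)CC2)c1` is unmeasured. It differs from compound 2 by carboxy(fluoro)methyl in place of 1-carboxyethyl on a saturated chain carbon bound to an aromatic carbon and a saturated ring carbon. Among the compounds with values here, the only measured step, from compound 1 to compound 2, is a change of configuration at this very carbon, not a change of group, so it bears on the new step only in showing that this position is sensitive. Within the data shown here, the swap of the methyl for fluorine has no measured counterpart here. The expectation for compound 3 is therefore a moderate step down, a 2.2-fold lower number from compound 2 to compound 3 (0.34 log units; beyond the scatter), but with wide uncertainty. Compound 3 is estimated at 1 nM, expected within 0.2 nM to 6 nM.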

Compound 3, half-maximal effective concentration: 54 nM
Compound 3: middle estimate off by 54-fold (1.73 log units), on the low side, outside the stated range (above it).
By their numbers in this assay, from the lowest: compound 1; then compound 2; then compound 3.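

Replacing methyl with fluoro on the saturated chain carbon bound to a carbonyl carbon and a saturated chain carbon gives a 270-fold higher number from compound 1 to compound 3 (2.43 log units; beyond the scatter) in this assay, and the comparison with the other methyl compound gives a 25-fold higher number from compound 2 to compound 3 (1.39 log units; beyond the scatter). The earlier pair showed only that configuration at this carbon matters, whereas these steps show that the identity of the small substituent there also has a large effect, and that neither methyl configuration comes close to the fluoro compound's number. Nothing at hand accounts for the size of these steps.

Still open, going by these compounds, is how the opposite configuration of the fluoro compound would read in this assay. Also open, on these data alone, is whether hydrogen, hydroxyl or ethyl on this carbon would keep the low numbers of the methyl compounds or follow compound 3.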